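This account rests on a few compounds, and the source may have more. Where it says the series, first, only, none or still open, it means among the compounds named here.

Compound 1, `Fc1ccc(CN2CCC(NCCSC(c3ccc(F)cc3)c3ccc(F)cc3)CC2)cc1`, gives 70% in an ADME assay on microsomes from liver (Rattus norvegicus) for metabolic stability, read by LC-MS, using NADPH, with a stated time of 60 min, tested at 10 uM; on this read-out higher numbers stand for a more stable compound and lower numbers for a less stable compound.
Compound 2, `OC(Cc1ccccc1)CN1CCC(NCCSC(c2ccc(F)cc2)c2ccc(F)cc2)CC1`, gives 74% in this assay.
Compound 3, `O=C(c1ccccc1)N1CCC(NCCSC(c2ccc(F)cc2)c2ccc(F)cc2)CC1`, gives 7% in this assay.

Compound 3 stands lowest of the three measured values in this assay. The step of a number 63 percentage points lower from compound 1 to compound 3 (beyond the scatter) and the step of a number 67 percentage points lower from compound 2 to compound 3 (beyond the scatter) are both large, while the step of a number 4 percentage points higher from compound 1 to compound 2 (within the scatter) lies within the scatter.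

Compound 4, `O=C(c1ccc(F)cc1)N1CCC(NCCSC(c2ccc(F)cc2)c2ccc(F)cc2)CC1`, has not yet been measured in this assay. It differs from compound 3 in one place: fluoro in place of hydrogen on an aromatic carbon.

Going by the values given here, none of the measured steps puts a fluoro in place of hydrogen on an aromatic carbon alone. The step closest in kind is a number 4 percentage points higher from compound 1 to compound 2 (within the scatter), in which a 4-fluorophenyl was exchanged for a group without fluorine together with other changes, and that step stayed within the scatter. The two large steps concern the benzoyl in place of a benzyl-type group on the ring nitrogen, which compound 3 and compound 4 share. On this basis a step no larger than the scatter is expected for a number 3 percentage points higher from compound 3 to compound 4 (within the scatter), in no clear direction. Compound 4 is therefore estimated at 10%, with a range from 3% to 25% in this assay.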

Compound 4, percent of the compound remaining: 24%
Compound 4: the middle estimate sits 14 percentage points below what was measured; the range from low to high includes it.
By their numbers in this assay, from the lowest: compound 3; then compound 4; then compounds 1 and 2 (each within the scatter of the next).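

In this assay, fluoro on an aromatic carbon, para to a large group, turns the benzoyl of compound 3 into the (4-fluorophenyl)carbonyl of compound 4 and gives a number 17 percentage points higher from compound 3 to compound 4 (beyond the scatter), so this single atom moves the number beyond the scatter, though only modestly. The change on the ring nitrogen still dominates, with a number 46 percentage points lower from compound 1 to compound 4 (beyond the scatter) and a number 50 percentage points lower from compound 2 to compound 4 (beyond the scatter), both large, so fluoro at this position recovers only part of the loss seen with the benzoyl of compound 3. The data offered here give no explanation for the rise.

From the compounds shown here alone, it remains open whether chloro, methoxy or a nitrile at the same place would give a similar step, or whether it is specific to fluoro. Going by these compounds, it is also open whether the same exchange on the benzyl group of compound 1 would change the number, which would show whether the step depends on the carbonyl.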